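Cytotoxicity notes: hydroxypropyl versus isopropyl amines

The source may report more compounds than this note shows. Statements on the series, on what has been measured and on what is new or still open speak of the compounds shown alone.

Measured compounds:
compound 1, `CC(O)CNC(c1ccnc(Nc2ccc(C#N)cc2)n1)c1ccccc1Cl`, 34700 nM
compound 2, `CC(C)NC(c1ccnc(Nc2ccc(C#N)cc2)n1)c1ccccc1Cl`, 35500 nM
compound 3, `CC(O)CNC(c1ccc(C#N)cc1)c1ccnc(Nc2ccc(C#N)cc2)n1`, reported only as a limit of the assay, > 65000 nM

All values come from an ADME assay on MT4 cells (Homo sapiens) for cytotoxicity, read by MTT assay, with a stated time of 5 days; on this read-out lower numbers stand for higher toxicity in this test and higher numbers for lower toxicity in this test. The change from compound 1 to compound 2 is isopropyl in place of 2-hydroxypropyl on an amine nitrogen; the step it made was a 1.0-fold higher number from compound 1 to compound 2 (0.01 log units; within the scatter). The two cores differ by 4-cyanophenyl in place of 2-chlorophenyl on a saturated chain carbon bound to an amine nitrogen and an aromatic carbon, and the step from compound 1 to compound 3 was an at least 1.8-fold higher number from compound 1 to compound 3 (0.27 log units; that floor lies within the scatter), read against a limit; the limit concerned is the limit of > 65000 nM in this assay, at which 1 of the 3 values shown sits.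

Compound 4, `CC(C)NC(c1ccc(C#N)cc1)c1ccnc(Nc2ccc(C#N)cc2)n1`, has not yet been run in this assay. For the measured compounds named here, it carries the same change as the one from compound 1 to compound 2, here (isopropyl in place of 2-hydroxypropyl on an amine nitrogen), and the place is the same word for word, so it is the same change made on the core of compound 3. Because a 1.0-fold higher number from compound 1 to compound 2 (0.01 log units; within the scatter) sat within the scatter, the step from compound 3 to compound 4 is expected to be a step that the limit leaves unreadable from compound 3 to compound 4, also within the scatter. Compound 4 is therefore estimated at 70000 nM, with a range from 40000 nM to 150000 nM, and a reading again at the limit is considered likely.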

Compound 4, half-maximal cytotoxic concentration: 69200 nM
Compound 4: the middle estimate sits 1.0-fold (0.00 log units) above what was measured; the range from low to high includes it.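

In this assay, for the compounds shown here, the one new step that can be read is a 1.9-fold higher number from compound 2 to compound 4 (0.29 log units; within the scatter), made by 4-cyanophenyl in place of 2-chlorophenyl on the isopropylamino series; the step from 2-hydroxypropyl to isopropyl on the core of compound 3 cannot be read. Set beside the same aryl change on the (2-hydroxypropyl)amino series, this step gives no sign of a difference between the two cores, but it does not establish that the change carries over unchanged: the same change on two cores in this assay, an at least 1.8-fold higher number (0.27 log units; that floor lies within the scatter) from compound 1 to compound 3 and a 1.9-fold higher number (0.29 log units; within the scatter) from compound 2 to compound 4; the limit leaves it open whether they differ Compound 3 is reported only as a limit of the assay, > 65000 nM, so the compounds shown neither confirm nor exclude that the amine change, within the scatter on the core of compound 1, carries over to the core of compound 3: the limit of > 65000 nM in this assay, at which 1 of the 4 values shown sits.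

Still open, as far as these compounds go, is how a longer chain or a carboxylic acid on the amine nitrogen would read in this assay. Equally open, from the compounds shown here alone, is how an unsubstituted phenyl in place of either aryl group would read there.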